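Benzyl on the Ring Nitrogen of a Piperidine Pyridone

The compounds below may be only part of what the source reports. "The series", "measured", "known", "first", "only" and "open" are said of these compounds alone.

Of the compounds shown here, two have so far been measured in an assay on HEK293 cells for displacement of a labelled ligand from Neuronal acetylcholine receptor; alpha3/beta2 (Rattus norvegicus), tested at 10 uM; on this read-out higher numbers stand for weaker inhibition and lower numbers for stronger inhibition. Compound 1 `O=c1ccccn1CC1CCCN(Cc2ccccc2)C1` carries a benzyl group on its ring nitrogen, and in this assay compound 1 gives 4300 nM. Compound 2 `O=c1ccccn1CC1CCNCC1` has a bare ring nitrogen, and in this assay compound 2 gives 12000 nM. Of the two numbers, compound 2 stands highest, and its gap to compound 1 lies beyond the usual scatter of repeated measurements.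

Compound 3 `O=c1ccccn1CC1CCN(Cc2ccccc2)CC1` has not yet been measured. It differs from compound 2 in one place: benzyl in place of hydrogen on an amine nitrogen in a ring. Compound 1 also bears a benzyl group on its ring nitrogen and gives 4300 nM in this assay; on that showing a lower number is expected for compound 3 too. The expected step is a 2.7-fold lower number from compound 2 to compound 3 (0.43 log units; beyond the scatter), a drop beyond the scatter. On this basis compound 3 is expected to give about 4500 nM in this assay, within a range from 1500 nM to 13000 nM.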

Compound 3, inhibition constant: 7300 nM
The estimate for compound 3 lay 1.6-fold (0.21 log units) below the measured number; measured number inside the range.
By their numbers in this assay, from the lowest: compounds 1, 3 and 2 (each within the scatter of the next, the first and the last beyond it).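

In this assay, placing benzyl in place of hydrogen on the amine nitrogen of the six-membered non-aromatic ring, three ring bonds from the ring atom that bears the group of 8 heavy atoms, gives a 1.6-fold lower number from compound 2 to compound 3 (0.22 log units; within the scatter), so at this position the numbers for the two compounds cannot be told apart. Among these compounds, this is the first comparison that isolates the benzyl group as the only difference, and it shows that this single change does not by itself reproduce the gap beyond the scatter seen between compound 1 and compound 2, which differ in more than one place. Nothing among the data shown offers a measured explanation for this outcome.

The compounds shown leave open whether a different group on this ring nitrogen, such as a methyl, a phenethyl chain or a benzoyl amide, would move the number beyond the scatter. They also leave open whether a fluorine or a methoxy group on the benzyl phenyl ring would alter the result for compound 3.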